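The source may report more compounds than this note shows. Statements on the series, on what has been measured and on what is new or still open speak of the compounds shown alone.

Compound 1 `O=C(/C=C/c1ccc(OCCCCCCO[N+](=O)[O-])c(O)c1)OCCCCCCO[N+](=O)[O-]` was tested in a functional assay on NCI-H157 cells (Homo sapiens) for cytotoxicity, read by resazurin assay, with a stated time of 72 h (on this read-out lower numbers stand for stronger inhibition and higher numbers for weaker inhibition), where compound 1 gives > 50000 nM, which is a limit of the assay rather than a number. Compound 2 `COc1cc(/C=C/C(=O)OCc2cccc(OCc3c(-c4ccccc4)no[n+]3[O-])c2)ccc1O` likewise gives a limit in this assay, > 50000 nM. Among the measured compounds shown here, compound 3 `COc1cc(/C=C/C(=O)Oc2cccc(OCc3c(-c4ccccc4)no[n+]3[O-])c2)ccc1O` is the only one with a number, giving 24700 nM in this assay. Compound 1 thus stands at the top end of what is shown, noted as the limit of > 50000 nM in this assay, at which 2 of the 3 values shown sit.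

Compound 4 `COc1cc(/C=C/C(=O)OCCCCCCO[N+](=O)[O-])ccc1OCCCCCCO[N+](=O)[O-]` differs from compound 1 by methyl in place of hydrogen on an oxygen on an aromatic ring. For the step from compound 1 to compound 4 in this assay, no shift beyond the scatter is expected. Compound 4 is therefore estimated at 60000 nM, between 25000 nM and 150000 nM, most likely again reported as a limit, with the expected step being a step that the limit leaves unreadable from compound 1 to compound 4.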

Compound 4, half-maximal inhibitory concentration: > 50000 nM
Compound 4 gave a limit, no number; the forecaster's own chance of this, stated with the estimate: 80%; the middle value lies beyond the limit too.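

Among the compounds shown here, compound 1 and compound 4 both give limits rather than numbers, so no step between them can be read. The compounds shown leave open whether going from hydroxy to methoxy changes the read-out at all.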